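Oxolane to isopropyl: what happens to solubility

A few compounds are considered here, and "the series" means these few. Any claim that something is new, unique, unknown or untested is made for them only; others in the source may bear on it.

Compound 1, `Nc1nccc(-c2cc(OC3CCOC3)c3c(N)n[nH]c3c2)n1`: 751000 nM
Compound 2, `Nc1nccc(-c2cc(OCc3ccccc3)c3c(N)n[nH]c3c2)n1`: 85000 nM

For the measured compounds named here, in a physicochemical assay for solubility, read by LC-MS, in phosphate buffer, measured as kinetic solubility, with a stated time of 24 h, at 25 degrees C, at pH 7.4 (on this read-out lower numbers stand for lower solubility and higher numbers for higher solubility), compound 1 gives 751000 nM, the highest of the two numbers known here. Compound 2 gives 85000 nM; the step of an 8.8-fold lower number from compound 1 to compound 2 (0.95 log units; beyond the scatter) shows that exchanging the ring on the oxygen for a larger group lowered the number beyond the scatter. Compound 3, `CC(C)Oc1cc(-c2ccnc(N)n2)cc2[nH]nc(N)c12`, differs from compound 1 by isopropyl in place of oxolan-3-yl on an oxygen on an aromatic ring. Going by the values given here, only this one measured step bears on the change: it shares the same place and the same leaving group, but the group entering in compound 3 is smaller than benzyl and has no ring. The expected step is therefore in the same direction but smaller, and compound 3 is estimated to give 300000 nM, in the range 120000 nM to 750000 nM, a change of a 2.5-fold lower number from compound 1 to compound 3 (0.40 log units; beyond the scatter) expected from compound 1.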

Compound 3, solubility: 354000 nM
For compound 3 the middle estimate is 1.2-fold (0.07 log units) below the measured one; low and high end bracket the measured number.
By their numbers in this assay, from the lowest: compound 2; then compound 3; then compound 1.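

In this assay isopropyl in place of oxolan-3-yl on the oxygen gives a 2.1-fold lower number from compound 1 to compound 3 (0.33 log units; beyond the scatter) and so shows that a group with no ring also reads lower than oxolan-3-yl. Isopropyl in place of benzyl gives a 4.2-fold higher number from compound 2 to compound 3 (0.62 log units; beyond the scatter) and places compound 3 between the other two compounds, with both steps beyond the scatter. At this place, on an oxygen on an aromatic ring, the three groups therefore give three separate numbers, with oxolan-3-yl highest and benzyl lowest. No measurement given here explains this order. The compounds shown also leave open how an amine, a carboxylic acid or a longer chain on this oxygen would read against these three groups.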